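The source may report more compounds than this note shows. Statements on the series, on what has been measured and on what is new or still open speak of the compounds shown alone.

The three measured analogues share one core. Compound 1 `CC(C)=CC[C@@H](OC[C@H](C)O)C1=CC(=O)c2c(O)ccc(O)c2C1=O` gives 40300 nM in a functional assay on HeLa cells (Homo sapiens) for cytotoxicity, read by MTT assay; on this read-out higher numbers stand for weaker inhibition and lower numbers for stronger inhibition. Compound 2 `CC(=O)OCCO[C@H](CC=C(C)C)C1=CC(=O)c2c(O)ccc(O)c2C1=O` gives 41500 nM in this assay, and the step of a 1.0-fold higher number from compound 1 to compound 2 (0.01 log units; within the scatter) shows that the change on the side chain left the number essentially where it was. Compound 3 `CCCCC(CC(=O)O[C@H](CC=C(C)C)C1=CC(=O)c2c(O)ccc(O)c2C1=O)OC(C)=O` gives 73500 nM, the highest of the three, though its gaps to compound 2 and compound 1 both stay within the scatter. Compound 4 `CC(C)=CC[C@@H](OC(=O)CC(C)(O)c1ccccc1)C1=CC(=O)c2c(O)ccc(O)c2C1=O` is the next case: 1-hydroxy-1-phenylethyl in place of 1-acetoxypentyl on a saturated chain carbon bound to a carbonyl carbon. Among the measured compounds shown here, no measured step touches the ester side of the chain, so the one step known offers no direction. Compound 4 is therefore expected to land at 60000 nM, between 30000 nM and 120000 nM, meaning a step of a 1.2-fold lower number from compound 3 to compound 4 (0.09 log units; within the scatter).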

Compound 4, half-maximal inhibitory concentration: 85700 nM
The estimate for compound 4 lay 1.4-fold (0.15 log units) below the measured number; low and high end bracket the measured number.
By their numbers in this assay, from the lowest: compounds 1, 2, 3 and 4 (each within the scatter of the next, the first and the last beyond it).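

In this assay, the step of a 1.2-fold higher number from compound 3 to compound 4 (0.07 log units; within the scatter) shows that, on a saturated chain carbon bound to a carbonyl carbon, 1-hydroxy-1-phenylethyl can replace 1-acetoxypentyl with the change staying within the scatter. The earlier step did not touch this place, and here even a six-membered aromatic ring entering for an open chain leaves no readable shift. No available evidence bears on why this is so. The compounds shown leave open whether an amine or a carboxylic acid at this place would move the number beyond the scatter.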